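Chloro for methyl on the methoxy-bearing ring

A few compounds are considered here, and "the series" means these few. Any claim that something is new, unique, unknown or untested is made for them only; others in the source may bear on it.

Three compounds of the series have numbers in an assay on HEK293 cells for displacement of a labelled ligand from prostaglandin D2 receptor 2 (Homo sapiens); on this read-out higher numbers stand for weaker inhibition and lower numbers for stronger inhibition. Compound 1 `O=C(O)Cn1c(SCc2cccc(Cl)c2)nc2ccccc21` gives 186 nM. Compound 2 `COc1ccccc1CSc1nc2ccccc2n1CC(=O)O` gives 1100 nM. Compound 3 `COc1ccc(C)cc1CSc1nc2ccccc2n1CC(=O)O` gives 1200 nM, the highest of the three numbers, with compound 2 nearest and compound 1 furthest, the gap to compound 1 lying beyond the scatter. Among the measured compounds shown here, the one single-point step seen so far, a 1.1-fold higher number from compound 2 to compound 3 (0.04 log units; within the scatter), concerns a methyl entering on an aromatic carbon and changes little.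

Compound 4 `COc1ccc(Cl)cc1CSc1nc2ccccc2n1CC(=O)O` differs from compound 3 by chloro in place of methyl on an aromatic carbon. For the measured compounds named here, no measured step covers a methyl-to-chloro exchange; compound 1 carries a chloro on its ring but differs from compound 4 in more than one place, so its value is only a loose pointer. With compound 2 and compound 3 showing that substitution on this ring barely moved the number, a step of no more than modest size in this assay is expected, leaning slightly toward a lower number because compound 1 gives 186 nM with a chloro present. For compound 4 the expected step is a 1.4-fold lower number from compound 3 to compound 4 (0.15 log units; within the scatter). The estimate for compound 4 is therefore 850 nM, within a range of 380 nM to 1900 nM.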

Compound 4, half-maximal inhibitory concentration: 740 nM
For compound 4 the middle estimate is 1.1-fold (0.06 log units) above the measured one, within the range that was stated.
By their numbers in this assay, from the lowest: compound 1; then compounds 4, 2 and 3 (each within the scatter of the next).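

Chloro at this place gives a 1.6-fold lower number from compound 3 to compound 4 (0.21 log units; within the scatter) and a 1.5-fold lower number from compound 2 to compound 4 (0.17 log units; within the scatter) in this assay, so hydrogen, methyl and chloro on the aromatic carbon para to a methoxy group cannot be told apart on this read-out. Among the compounds shown here, with the chloro kept, methoxy in place of hydrogen gives a 4.0-fold higher number from compound 1 to compound 4 (0.60 log units; beyond the scatter) and is the only one of these new steps beyond the scatter, which makes the methoxy group, and not the group para to it, the change on this ring that registers so far. Nothing on hand accounts for either finding.

On these data alone, whether an amine, a nitrile or a trifluoromethyl at this place would move the number beyond the scatter remains open. Also open, as far as these compounds go, is whether an ethoxy or hydroxy group in place of the methoxy group would give a step of similar size.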